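The compounds below may be only part of what the source reports. "The series", "measured", "known", "first", "only" and "open" are said of these compounds alone.

In a functional assay on MCF7 cells (Homo sapiens) for cytotoxicity, read by MTT assay, with a stated time of 72 h (a higher number here means a weaker inhibitor, a lower number a stronger inhibitor), compound 3 `FC(F)(F)c1ccc(CSc2nc(Nc3ccccc3Cl)c3ccccc3n2)cc1` gives only a limit, > 50000 nM. Compound 1 `CCCCCCCCCCCCNc1nc(SCc2ccc(C(F)(F)F)cc2)nc2ccccc12` also reaches only the limit, > 50000 nM. Compound 2 `CCCCCCCCCCCCCCNc1nc(SCc2ccc(C(F)(F)F)cc2)nc2ccccc12` likewise gives the limit, > 50000 nM. The step that the two limits leave unreadable from compound 1 to compound 2 is thus not readable, and the limit of > 50000 nM in this assay, at which 3 of the 3 values shown sit, is where every measured value stands. Compound 4 `O=[N+]([O-])c1cccc(Nc2nc(SCc3ccc(C(F)(F)F)cc3)nc3ccccc23)c1` differs from compound 3 by 3-nitrophenyl in place of 2-chlorophenyl on a nitrogen on an aromatic ring. No measured step bears on this change, and the one step shown, the chain extension, is itself unreadable, so there is no ground to expect a move beyond the scatter in either direction in this assay. Compound 4 is expected to remain near the same limit, with an estimated value of 50000 nM, ranging from 15000 nM to 150000 nM. The expected step is a number no higher from compound 3 to compound 4 (the limit leaves the size open).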

Compound 4, half-maximal inhibitory concentration: > 50000 nM
Compound 4: a limit, no number; the forecaster's own chance of this, stated with the estimate: 80%; the middle value lies on the limit itself.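

No new step can be read between compound 3 and compound 4, as both give only a limit: the limit of > 50000 nM in this assay, at which 4 of the 4 values shown sit.

The compounds shown leave open how far any of them lies past that limit, and so whether either change shifts cytotoxicity at all.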